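A few compounds are considered here, and "the series" means these few. Any claim that something is new, unique, unknown or untested is made for them only; others in the source may bear on it.

Within the data shown here, in a functional assay on HT-29 cells (Homo sapiens) for cytotoxicity, read by MTT assay, with a stated time of 24 h (a lower number here means a stronger inhibitor, a higher number a weaker inhibitor), compound 1 `C#CCOc1ccccc1/C=N/Cc1ccc(S(N)(=O)=O)cc1` gives 31000 nM, the lowest of the three numbers measured so far. Compound 2 `C#CCOc1c(/C=N/Cc2ccc(S(N)(=O)=O)cc2)cccc1OC` gives 81300 nM, and compound 3 `C#CCOc1cc(N(CC)CC)ccc1/C=N/Cc1ccc(S(N)(=O)=O)cc1` gives 62800 nM. Compound 4 `C#CCOc1ccc(Br)cc1/C=N/Cc1ccc(S(N)(=O)=O)cc1` differs from compound 1 by one change: bromo in place of hydrogen on an aromatic carbon. Two measured steps also replace a hydrogen on an aromatic carbon: methoxy gives a 2.6-fold higher number from compound 1 to compound 2 (0.42 log units; beyond the scatter), and diethylamino gives a 2.0-fold higher number from compound 1 to compound 3 (0.31 log units; beyond the scatter). Both are modest and both rise, but neither involves bromo, so a somewhat smaller rise is expected, one that may stay within the scatter. The expected step is a 1.6-fold higher number from compound 1 to compound 4 (0.21 log units; within the scatter). Compound 4 is estimated at 50000 nM, with an expected range of 20000 nM to 110000 nM.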

Compound 4, half-maximal inhibitory concentration: 45700 nM
Compound 4: middle estimate off by 1.1-fold (0.04 log units), on the high side; the measured number falls inside the stated range.
By their numbers in this assay, from the lowest: compounds 1, 4, 3 and 2 (each within the scatter of the next, the first and the last beyond it).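

In this assay bromo in place of hydrogen, para to a propargyloxy group, gives a 1.5-fold higher number from compound 1 to compound 4 (0.17 log units; within the scatter) and so leaves the number of compound 1 unchanged within the scatter. Among these compounds, the earlier steps, with methoxy in compound 2 and diethylamino in compound 3, both lie beyond the scatter, so compound 4 is the first single replacement on this ring that does not separate from compound 1. Nothing available explains this result.

The compounds shown leave open whether an amine or a carboxylic acid at this position would also stay within the scatter of compound 1. They also leave open whether fluoro or chloro would match bromo here.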